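Benzyloxycarbonyl on the ring amine of a weak MCF7 inhibitor

The compounds below may be only part of what the source reports. "The series", "measured", "known", "first", "only" and "open" are said of these compounds alone.

Measured compounds:
compound 1, `Fc1ccccc1Cn1cc(CSC(=S)N2CCNCC2)nn1`: 33200 nM
compound 2, `S=C(SCc1cn(Cc2ccc(Cl)cc2)nn1)N1CCNCC1`: "not determined" (no result reported)

Compound 1, `Fc1ccccc1Cn1cc(CSC(=S)N2CCNCC2)nn1`, carries a free amine nitrogen in its six-membered ring; in a functional assay on MCF7 cells (Homo sapiens) for inhibition, read by MTT assay, with a stated time of 72 h (on this read-out higher numbers stand for weaker inhibition and lower numbers for stronger inhibition), compound 1 gives 33200 nM, which marks it as a weak inhibitor. Going by the values given here, compound 2, `S=C(SCc1cn(Cc2ccc(Cl)cc2)nn1)N1CCNCC1`, differs in its aryl ring, but in this assay compound 2 gives "not determined" (no result reported), so compound 1 stands as the only measured value here and no ordering among the measured compounds can be drawn.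

Compound 3, `O=C(OCc1ccccc1)N1CCN(C(=S)SCc2cn(Cc3ccccc3F)nn2)CC1`, is obtained from compound 1 by the change (benzyloxycarbonyl in place of hydrogen on an amine nitrogen in a ring). Among the compounds with values here, no pair of measured compounds shows what such a change does on the shared core, so the direction of the step is open. A step from compound 1 to compound 3 that stays within, or only just beyond, the scatter is expected: a 1.3-fold lower number from compound 1 to compound 3 (0.12 log units; within the scatter). On that basis compound 3 is estimated to give 25000 nM in this assay, with a range from 6000 nM to 100000 nM.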

Compound 3, half-maximal inhibitory concentration: 7950 nM
The estimate for compound 3 lay 3.1-fold (0.50 log units) above the measured number; the range from low to high includes it.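

Benzyloxycarbonyl in place of hydrogen on the amine nitrogen in the ring gives a 4.2-fold lower number from compound 1 to compound 3 (0.62 log units; beyond the scatter) in this assay and so provides the first measured step at this position. The free amine hydrogen of compound 1 is therefore not required for inhibition at this level, and the nitrogen can carry the full benzyloxycarbonyl group without a loss of inhibition. Nothing shown here explains why the number falls.

Going by these compounds, whether this step depends on the whole benzyloxycarbonyl group or would also follow from a simpler acetyl or methyl group on the same nitrogen remains open. Going by these compounds alone, with only one step at this position, it is also unknown whether the change would have the same effect on another aryl ring, such as the chlorobenzyl of compound 2, which has no reported result.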